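A phenyl ring at the end of the heptyloxy chain

A few compounds are considered here, and "the series" means these few. Any claim that something is new, unique, unknown or untested is made for them only; others in the source may bear on it.

Compound 1 `CCCCCCCOc1cc(CCc2nc(C)c(CC)s2)nc(NCc2cc(Cl)cc(NC(=O)OC(C)C)c2)c1` gives 72 nM in an assay on cells for binding affinity to Neuropeptide Y receptor type 1 (Homo sapiens) (a lower number here means a stronger inhibitor, a higher number a weaker inhibitor), the highest of the three numbers measured. Compound 2 `CCc1sc(CCc2cc(OC(C)C)cc(NCc3cc(Cl)cc(NC(=O)OC(C)C)c3)n2)nc1C` gives 12 nM, and compound 3 `CCc1sc(CCc2cc(OC3CCOCC3)cc(NCc3cc(Cl)cc(NC(=O)OC(C)C)c3)n2)nc1C` gives 4.4 nM. Both measured steps replace the heptyl group: a 6.0-fold lower number from compound 1 to compound 2 (0.78 log units; beyond the scatter), and a 16-fold lower number from compound 1 to compound 3 (1.21 log units; beyond the scatter). Compound 4 `CCc1sc(CCc2cc(OCCCc3ccccc3)cc(NCc3cc(Cl)cc(NC(=O)OC(C)C)c3)n2)nc1C` differs from compound 1 by phenyl in place of butyl on a saturated chain carbon, three bonds along the chain from an oxygen on an aromatic ring. This change also shortens the heptyl chain, but keeps a larger group on the oxygen than compound 2 or compound 3 carry, so only a modest step is expected, namely a 2.4-fold lower number from compound 1 to compound 4 (0.38 log units; beyond the scatter). Compound 4 is therefore estimated to give 30 nM, within a range from 10 nM to 90 nM.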

Compound 4, half-maximal inhibitory concentration: 20 nM
Compound 4: the middle estimate sits 1.5-fold (0.18 log units) above what was measured, and the stated range covers the measured number.
By their numbers in this assay, from the lowest: compound 3; then compounds 2 and 4 (each within the scatter of the next); then compound 1.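

In this assay, phenyl in place of butyl on the chain gives a 3.6-fold lower number from compound 1 to compound 4 (0.56 log units; beyond the scatter), so moving away from heptyl does not require a group on the oxygen as short as isopropyl. The 3-phenylpropyl group cannot be told apart from isopropyl, with a 1.7-fold higher number from compound 2 to compound 4 (0.22 log units; within the scatter), while going from oxan-4-yl to 3-phenylpropyl gives a 4.5-fold higher number from compound 3 to compound 4 (0.66 log units; beyond the scatter). No measurement available here accounts for these steps. The compounds shown leave open whether benzyl or phenethyl on the oxygen, or an amine on the chain, would give a lower number than 3-phenylpropyl does.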